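The Same Trifluoromethyl Step on Two Different Cores

A few compounds are considered here, and "the series" means these few. Any claim that something is new, unique, unknown or untested is made for them only; others in the source may bear on it.

Measured so far:
Compound 3, `COc1ccc(Cn2nc(-c3ccccc3)c3cc(C(=N)Nc4ccccc4)nc(NC4CCCCC4)c32)cc1`: in a functional assay on MDA-MB-231 cells (Homo sapiens) for cytotoxicity, read by MTT assay, with a stated time of 72 h (a lower number here means a stronger inhibitor, a higher number a weaker inhibitor), compound 3 gives 3400 nM.
Compound 1, `COc1ccc(Cn2nc(-c3ccccc3)c3cc(C(=N)Nc4cccc(C(F)(F)F)c4)nc(NC4CCCCC4)c32)cc1`: in this assay compound 1 gives > 50000 nM, which is a limit of the assay and not a number.
Compound 2, `N=C(Nc1ccccc1)c1cc2cn[nH]c2cn1`: in this assay compound 2 gives > 50000 nM, again a limit of the assay.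

Compound 1 and compound 3 differ in one place only: trifluoromethyl in place of hydrogen on an aromatic carbon. That change brought an at least 14-fold higher number from compound 3 to compound 1 (1.16 log units; beyond the scatter), so the step is large and points toward weaker inhibition. How large it really is cannot be said, because the limit of > 50000 nM in this assay, at which 2 of the 3 values shown sit, caps what the assay reports.

Compound 4, `N=C(Nc1cccc(C(F)(F)F)c1)c1cc2cn[nH]c2cn1`, has not yet been measured. It differs from compound 2 by trifluoromethyl in place of hydrogen on an aromatic carbon, the same change as from compound 3 to compound 1, sitting at the same kind of place. The difference between the core of compound 2 and the core of compound 3 is not broken down here; compound 2 is the much smaller of the two and already sits at the limit.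

For compound 4 the expected step is a step that the limit leaves unreadable from compound 2 to compound 4 in this assay, because an at least 14-fold higher number from compound 3 to compound 1 (1.16 log units; beyond the scatter) went the weakening way with this same change. Compound 4 is therefore estimated at 100000 nM, with a range from 50000 nM to 500000 nM, most likely reported as a limit once more.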

Compound 4, half-maximal inhibitory concentration: > 50000 nM
Compound 4 ended at the assay's limit; the forecaster's own chance of this, stated with the estimate: 90%; the middle value lies beyond the limit too.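

Compound 2 and compound 4 both sit at a limit of this assay and not at a number, so the trifluoromethyl step between them cannot be read: the limit of > 50000 nM in this assay, at which 3 of the 4 values shown sit.

The compounds shown leave open whether trifluoromethyl in place of hydrogen changes the number at all on the core of compound 2, as it did on the core of compound 3.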